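The source may hold more compounds than are shown below. What is called first, only, known or untested is meant among the compounds shown, and "the series" means these compounds.

Measured compounds:
Compound 1, `Nc1scc(CN2CCN(c3cccc(F)c3)CC2)c1C(=O)c1cccc(C(F)(F)F)c1`, in an assay on CHO cells for displacement of a labelled ligand from adenosine receptor A1 (Homo sapiens), read by scintillation counting, with a stated time of 120 min, tested at 10 uM (a higher number here means more inhibition at the concentration tested (going by the name of the read-out), a lower number less inhibition), compound 1 gives 0%.
Compound 2, `Nc1scc(CN2CCN(c3c(F)cccc3F)CC2)c1C(=O)c1cccc(C(F)(F)F)c1`, in this assay compound 2 gives 0%.
Compound 3, `Nc1scc(CN2CCN(c3cccc4ccccc34)CC2)c1C(=O)c1ccc(Cl)cc1`, in this assay compound 3 gives 1%.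

All three compounds share a core, and in this assay none of them shows appreciable displacement. Compound 3 stands level with compounds 1 and 2: its number differs from each of theirs by an amount that lies inside the usual scatter, so the three cannot be told apart. For the measured compounds named here, the one step measured within this set, no change at the digits printed from compound 1 to compound 2 (within the scatter), changed the aryl group on the ring amine nitrogen without moving the read-out beyond the scatter.

Compound 4, `Nc1scc(CN2CCN(c3ccc(Cl)c(Cl)c3)CC2)c1C(=O)c1ccc(Cl)cc1`, is not yet measured. It differs from compound 3 as follows: 3,4-dichlorophenyl in place of naphthalen-1-yl on an amine nitrogen in a ring. This is again a change of the aryl group on the ring amine nitrogen, the same kind of change as from compound 1 to compound 2, which left this assay unmoved. On that basis the step of a number 1 percentage points higher from compound 3 to compound 4 (within the scatter) is expected to stay within the scatter. Compound 4 is therefore estimated to give 2% in this assay, with a range from -8% to 12%.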

Compound 4, a percentage reported as inhibition, at one concentration (the size of the read-out at that concentration, not a potency): 1%
Compound 4: middle estimate off by 1 percentage points, on the high side; the measured number falls inside the stated range.
By their numbers in this assay, from the lowest: compounds 1, 2, 3 and 4 (each within the scatter of the next).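

In this assay the swap of naphthalen-1-yl for 3,4-dichlorophenyl on the amine nitrogen in the ring gives no change at the digits printed from compound 3 to compound 4 (within the scatter) and so leaves the read-out where it was. The earlier step at this position only exchanged 3-fluorophenyl for 2,6-difluorophenyl, whereas this one goes from two six-membered aromatic rings to one and brings in chlorine, so a wider change of the aryl group also leaves no mark. Nothing supplied here accounts for this flat result.

All four numbers lie close to zero, so these compounds cannot show whether any group at this position would raise the read-out or whether a step downward would register at all. On these data alone, whether a pyridine ring, a benzyl group or an acetyl group on that nitrogen would behave the same remains open.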